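This account rests on a few compounds, and the source may have more. Where it says the series, first, only, none or still open, it means among the compounds named here.

Measured so far in a functional assay on B16 cells (Mus musculus) for cytotoxicity, read by MTT assay; on this read-out higher numbers stand for weaker inhibition and lower numbers for stronger inhibition:
compound 1, `CC(=O)O[C@@H]1OC(=O)[C@](OC(C)=O)(C(C)=O)[C@@H]1C`: > 50000 nM (a limit of the assay, not a number)
compound 2, `CC(=O)O[C@@H]1OC(=O)[C@](OC(=O)c2ccccc2)(C(C)=O)[C@@H]1C`: 6000 nM
compound 3, `CC(=O)O[C@@H]1OC(=O)[C@@](C)(C(C)=O)[C@@H]1C`: 14000 nM.

For compound 1 only a limit is known, (the limit of > 50000 nM in this assay, at which 1 of the 3 values shown sits). Compound 2 differs from compound 1 by phenyl in place of methyl on a carbonyl carbon, and this change gave an at least 8.3-fold lower number from compound 1 to compound 2 (0.92 log units; beyond the scatter). Compound 3 gives the highest of the two measured numbers; the gap to compound 2 is beyond the scatter. The difference between the core of compound 3 and the core of compound 1 is not broken down here.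

Compound 4, `CC(=O)O[C@@H]1OC(=O)[C@@](C)(C(=O)c2ccccc2)[C@@H]1C`, is not yet measured. It differs from compound 3 by phenyl in place of methyl on a carbonyl carbon. This is the same kind of change as from compound 1 to compound 2, not the same: in compound 1 the carbonyl carbon's other neighbour is an oxygen next to a carbonyl group, in compound 3 it is a saturated ring carbon. A lower number is expected for compound 4, estimated at a 3.1-fold lower number from compound 3 to compound 4 (0.49 log units; beyond the scatter), resting on the earlier step of an at least 8.3-fold lower number from compound 1 to compound 2 (0.92 log units; beyond the scatter), but smaller since the place differs. Compound 4 is thus estimated at 4500 nM, between 1500 nM and 14000 nM.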

Compound 4, half-maximal inhibitory concentration: 7000 nM
For compound 4 the middle estimate is 1.6-fold (0.19 log units) below the measured one; measured number inside the range.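

On the core of compound 3, phenyl in place of methyl on a carbonyl carbon gives, in this assay, a 2.0-fold lower number from compound 3 to compound 4 (0.30 log units; within the scatter), so this step alone does not separate the two compounds on this read-out. The size of the step does not carry over from one core to the other: the same change on two cores in this assay, an at least 8.3-fold lower number (0.92 log units; beyond the scatter) from compound 1 to compound 2 and a 2.0-fold lower number (0.30 log units; within the scatter) from compound 3 to compound 4, at least 4.1-fold (0.61 log units) apart, beyond the scatter of two such steps. Going by these compounds, compound 1 stands at > 50000 nM, which is a limit of the assay and not a number, so the true size of the earlier step stays unknown, and two cores do not show which feature of them goes with the gap.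

Open, on these data alone, is how a longer chain such as propyl, or a phenyl ring carrying an amine or a carboxylic acid, would read on this carbonyl carbon on either core. Also open, as far as these compounds go, is whether a third core would follow the larger step, the smaller step or neither.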